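The source may hold more compounds than are shown below. What is called first, only, known or untested is meant among the compounds shown, and "the series" means these compounds.

Three compounds share one core and differ only in the aryl group on the carbon with a double bond to nitrogen. Compound 1 `COc1ccc(/C=N/NC(=O)Nc2ccc(Oc3ccnc(-c4nncn4CCN(C)C)c3)c(F)c2)c(OC)c1` gives 2820 nM in a functional assay on A549 cells (Homo sapiens) for cytotoxicity, read by MTT assay, with a stated time of 72 h; on this read-out higher numbers stand for weaker inhibition and lower numbers for stronger inhibition. Compound 2 `COc1ccc(/C=N/NC(=O)Nc2ccc(Oc3ccnc(-c4nncn4CCN(C)C)c3)c(F)c2)c(OC)c1OC` gives 6680 nM, and compound 3 `CN(C)CCn1cnnc1-c1cc(Oc2ccc(NC(=O)N/N=C/c3ccc(Cl)cc3)cc2F)ccn1` gives 780 nM, the lowest of the three numbers. Compound 4 `CN(C)CCn1cnnc1-c1cc(Oc2ccc(NC(=O)N/N=C/c3ccc(O)cc3)cc2F)ccn1` carries hydroxy in place of chloro on an aromatic carbon. For the measured compounds named here, the steps that bear on this change are a 3.6-fold lower number from compound 1 to compound 3 (0.56 log units; beyond the scatter) and an 8.6-fold lower number from compound 2 to compound 3 (0.93 log units; beyond the scatter), where oxygen-bearing aryls gave higher numbers than the chlorophenyl, and a 2.4-fold higher number from compound 1 to compound 2 (0.37 log units; beyond the scatter), where a further methoxy raised the number again. Compound 4 is therefore expected to give a modestly higher number than compound 3, a step of about a 2.6-fold higher number from compound 3 to compound 4 (0.41 log units; beyond the scatter), and its estimated value is 2000 nM, within a range from 700 nM to 6000 nM.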

Compound 4, half-maximal inhibitory concentration: 3560 nM
The estimate for compound 4 lay 1.8-fold (0.25 log units) below the measured number; low and high end bracket the measured number.
By their numbers in this assay, from the lowest: compound 3; then compounds 1, 4 and 2 (each within the scatter of the next, the first and the last beyond it).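

In this assay, hydroxy in place of chloro, para to a large group, gives a 4.6-fold higher number from compound 3 to compound 4 (0.66 log units; beyond the scatter) and so shows that a single hydroxy, with no methoxy present, is enough to separate the aryl from the 4-chlorophenyl. The steps of a 1.9-fold lower number from compound 2 to compound 4 (0.27 log units; within the scatter) and a 1.3-fold higher number from compound 1 to compound 4 (0.10 log units; within the scatter) leave the 4-hydroxyphenyl unseparated from either methoxy-bearing aryl, though a 2.4-fold higher number from compound 1 to compound 2 (0.37 log units; beyond the scatter) still separates those two aryls from each other.

On these data alone, whether bromo, fluoro or an amine at this place would stay with chloro or with hydroxy remains open. Nothing shown gives a reason for the step from chloro to hydroxy.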